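A few compounds are considered here, and "the series" means these few. Any claim that something is new, unique, unknown or untested is made for them only; others in the source may bear on it.

Compound 1 `CCCCOc1c(-c2cc(OC)c(OC)c(OC)c2)oc2ccccc2c1=O` — a limit of the assay: > 50000 nM
Compound 2 `CCCC(C)Oc1c(-c2cc(OC)c(OC)c(OC)c2)oc2ccccc2c1=O` — a limit of the assay: > 50000 nM
Compound 3 `CCCN(CCC)CCCCOc1c(-c2cc(OC)c(OC)c(OC)c2)oc2ccccc2c1=O` — 35800 nM

In a functional assay on DU-145 cells (Homo sapiens) for antiproliferative activity, read by WST assay, with a stated time of 3 days (on this read-out higher numbers stand for weaker inhibition and lower numbers for stronger inhibition), compound 1 stands at the limit of > 50000 nM in this assay, at which 2 of the 3 values shown sit, so only a limit and no number is known for it. Compound 2 also sits at that limit, and the step that the two limits leave unreadable from compound 1 to compound 2 therefore cannot be read. Compound 4 `CCCCN(CCCC)CCCOc1c(-c2cc(OC)c(OC)c(OC)c2)oc2ccccc2c1=O` differs from compound 1 by dibutylamino in place of methyl on a saturated chain carbon, three bonds along the chain from an oxygen on an aromatic ring. The closest measured steps are an at least 1.3-fold lower number from compound 1 to compound 3 (0.14 log units; that floor lies within the scatter) and an at least 1.3-fold lower number from compound 2 to compound 3 (0.14 log units; that floor lies within the scatter), each resting on a limit and each with a floor inside the scatter. By estimate the step is expected to be an at least 1.6-fold lower number from compound 1 to compound 4 (0.22 log units; that floor lies within the scatter). Compound 4 is thus expected at 30000 nM, within a range of 10000 nM to 60000 nM.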

Compound 4, half-maximal inhibitory concentration: 15700 nM
Beside the measured number, compound 4's estimate is 1.9-fold (0.28 log units) above it; measured number inside the range.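

In this assay, an amine-bearing chain on the oxygen now gives steps beyond the scatter, an at least 3.1-fold lower number from compound 1 to compound 4 (0.50 log units; beyond the scatter) and an at least 3.1-fold lower number from compound 2 to compound 4 (0.50 log units; beyond the scatter), whereas compound 3 had shown only floors within it. Both steps are floors because compound 1 and compound 2 sit at a limit: the limit of > 50000 nM in this assay, at which 2 of the 4 values shown sit.

Among the two amines, the data show a 2.3-fold lower number from compound 3 to compound 4 (0.36 log units; beyond the scatter), a change that alters the chain and the groups on the nitrogen together. The compounds shown leave open which of those two changes carries the step, and whether a piperidine in place of dibutylamino or a longer chain would lower the number further.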